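This account rests on a few compounds, and the source may have more. Where it says the series, first, only, none or still open, it means among the compounds named here.

Measured so far:
- Compound 1, `COc1ccc(CNc2cc(OC)c(OC)c(OC)c2)cc1Br`: 39800 nM
- Compound 2, `COc1ccc(CNc2cc(OC)c(OC)c(OC)c2)cc1`: 4890 nM

Both compounds were tested in a functional assay on KYSE-450 cells (Homo sapiens) for inhibition, read by MTT assay, with a stated time of 48 h; on this read-out lower numbers stand for stronger inhibition and higher numbers for weaker inhibition. Within the data shown here, of the two numbers, compound 2 gives the lower one; the only comparison is an 8.1-fold lower number from compound 1 to compound 2 (0.91 log units; beyond the scatter), so compound 2 stands well apart from compound 1 on this read-out.

Compound 3, `COc1cc(NCc2ccc(Cl)cc2)cc(OC)c1OC`, has not yet been measured. It differs from compound 2 in one place: chloro in place of methoxy on an aromatic carbon. Among the measured compounds shown here, the one measured step, from compound 1 to compound 2, concerns the loss of a bromo group, not the exchange of a methoxy for a chloro, so it does not bear directly on this change. What it does show is that a single change on that ring can move the number by an amount that is beyond the scatter. For the measured compounds named here, with no close precedent, the expectation for compound 3 is a step that may be no larger than the scatter or a modest rise, as expressed by a 1.6-fold higher number from compound 2 to compound 3 (0.21 log units; within the scatter). Compound 3 is therefore estimated at 8000 nM, with a plausible range from 2500 nM to 25000 nM.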

Compound 3, half-maximal inhibitory concentration: > 80000 nM
Compound 3 was reported as a limit (the forecaster's own chance of this, stated with the estimate: 5%); at least 10-fold (1.00 log units) between middle value and limit.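

In this assay, putting chloro in place of methoxy on the aromatic carbon para to a large group gives an at least 16-fold higher number from compound 2 to compound 3 (1.21 log units; beyond the scatter), a large step towards weaker inhibition. Among these compounds, the earlier step concerned only the loss of a bromo group, so this is the first sign that the group at this position matters, with methoxy here giving much stronger inhibition than chloro in this pair. Compound 3 is reported only as a limit, so the step gives a minimum size and not an exact one: the limit of > 80000 nM in this assay, at which 1 of the 3 values shown sits.

The compounds shown carry only methoxy or chloro at this position, so they cannot tell whether methoxy supports the inhibition, chloro harms it, or both are true. A hydroxyl group, an amine or a longer ether chain at the same position would help to separate these possibilities, and the data shown do not say what lies behind the drop.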